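Swapping the Ester Chain for an Amine on the Far Ring

The source may hold more compounds than are shown below. What is called first, only, known or untested is meant among the compounds shown, and "the series" means these compounds.

Of the compounds shown here, three sharing one core have been tested in a functional assay for agonist activity at G protein-coupled receptor 88 (Homo sapiens), read by HTRF and cAMP accumulation; a higher number here means that more compound is needed for the effect, a lower number that less compound is needed. Compound 1 `CC[C@H](C)[C@H](N)CN(C(=O)[C@@H]1C[C@H]1c1ccccc1)c1ccc(-c2ccc(OC(F)(F)F)cc2)cc1` gives 170 nM, compound 2 `CC[C@H](C)[C@H](N)CN(C(=O)[C@@H]1C[C@H]1c1ccccc1)c1ccc(-c2ccc(CO)cc2)cc1` gives 1100 nM, and compound 3 `CC[C@H](C)[C@H](N)CN(C(=O)[C@@H]1C[C@H]1c1ccccc1)c1ccc(-c2ccc(CCC(=O)OC)cc2)cc1` gives 110 nM. Compound 3 has the lowest number of the three, but its distance to compound 1 stays within the scatter, a 1.5-fold lower number from compound 1 to compound 3 (0.19 log units; within the scatter), so those two cannot be ranked; only compound 2 clearly stands apart, a 10-fold lower number from compound 2 to compound 3 (1.00 log units; beyond the scatter).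

Compound 4 `CC[C@H](C)[C@H](N)CN(C(=O)[C@@H]1C[C@H]1c1ccccc1)c1ccc(-c2ccc(N)cc2)cc1` has not yet been measured. It differs from compound 3 on the outer ring: amino in place of 2-(methoxycarbonyl)ethyl on an aromatic carbon. For the measured compounds named here, two measured steps bear on this. Putting hydroxymethyl in place of trifluoromethoxy on that ring gave a 6.5-fold higher number from compound 1 to compound 2 (0.81 log units; beyond the scatter), and moving from that hydroxymethyl to the longer ester chain gave a 10-fold lower number from compound 2 to compound 3 (1.00 log units; beyond the scatter). The amino group entering in compound 4 is, like hydroxymethyl, a short group that brings a hydrogen-bond donor, whereas the leaving ester chain brought none. The expected step in this assay is therefore upward, an 8.2-fold higher number from compound 3 to compound 4 (0.91 log units; beyond the scatter), toward the region of compound 2. Compound 4 is estimated at 900 nM, with a range from 300 nM to 3000 nM.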

Compound 4, half-maximal effective concentration: 320 nM
For compound 4 the middle estimate is 2.8-fold (0.45 log units) above the measured one, and the stated range covers the measured number.
By their numbers in this assay, from the lowest: compounds 3, 1 and 4 (each within the scatter of the next, the first and the last beyond it); then compound 2.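

In this assay, the position on the outer ring accepts a far smaller group than the ester chain without the number climbing to that of compound 2: replacing the 6 heavy atoms of 2-(methoxycarbonyl)ethyl with the 1 heavy atom of amino gives a 2.9-fold higher number from compound 3 to compound 4 (0.46 log units; beyond the scatter), a real but limited rise. Compared with hydroxymethyl, amino gives a 3.4-fold lower number from compound 2 to compound 4 (0.54 log units; beyond the scatter), so among these compounds a short group carrying a hydrogen-bond donor does not by itself lead to a number like that of compound 2, and compound 2 remains the only one clearly apart from the other three. Amino and trifluoromethoxy cannot be told apart, at a 1.9-fold higher number from compound 1 to compound 4 (0.27 log units; within the scatter), so two very different groups serve about equally here, and no measurement at hand explains why.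

On these data alone, it remains open whether aminomethyl would behave like amino or like hydroxymethyl, which would help separate the effect of the nitrogen from that of the added carbon. As far as these compounds go, it is also open whether a carboxylic acid at the end of the ester chain, or a methylamino group, would keep the number in the range of compound 3.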